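The compounds below may be only part of what the source reports. "The series", "measured", "known", "first", "only" and "open" are said of these compounds alone.

Working notes on the series. Compound 1, `CC(C)CNc1ccc(NC(=O)c2cc(Cl)ccc2O)c(Cl)c1`, is a salicylanilide-type amide carrying an isobutylamino group. Within the data shown here, in an ADME assay on A549 cells (Homo sapiens) for cytotoxicity, read by resazurin assay, with a stated time of 48 h (on this read-out higher numbers stand for lower toxicity in this test and lower numbers for higher toxicity in this test), compound 1 gives 60000 nM, the highest of the two numbers measured so far. Compound 2, `CC1(ON(c2ccc(NC(=O)c3cc(Cl)ccc3O)c(Cl)c2)C2(C)CCCC2)CCCC1`, carries a much larger substituent on the same aniline nitrogen; in this assay compound 2 gives 18000 nM, a gap from compound 1 that is beyond the scatter.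

Compound 3, `O=C(Nc1ccc(NCc2cc(Cl)cc(Cl)c2)cc1Cl)c1cc(Cl)ccc1O`, is the next analogue. Relative to compound 1 the change is 3,5-dichlorophenyl in place of isopropyl on a saturated chain carbon bound to a nitrogen on an aromatic ring. Among the measured compounds shown here, no measured pair shows this particular change, so its effect can only be guessed. The expectation is a small step toward higher toxicity, a 1.7-fold lower number from compound 1 to compound 3 (0.23 log units; within the scatter), perhaps within the scatter. For compound 3 the estimate in this assay is 35000 nM, with a range of 12000 nM to 90000 nM.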

Compound 3, half-maximal cytotoxic concentration: 13300 nM
Compound 3: the middle estimate sits 2.6-fold (0.42 log units) above what was measured, and the stated range covers the measured number.
By their numbers in this assay, from the lowest: compounds 3 and 2 (each within the scatter of the next); then compound 1.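

Among these compounds, exchanging isopropyl for 3,5-dichlorophenyl on a saturated chain carbon bound to a nitrogen on an aromatic ring gives the first single-place step: in this assay the change produces a 4.5-fold lower number from compound 1 to compound 3 (0.65 log units; beyond the scatter) and so moves modestly toward higher toxicity in this test. The entering group adds a six-membered aromatic ring of carbon only and two chlorine atoms, while neither group brings hydrogen-bond donors or acceptors, so this position responds measurably to a change that leaves those counts untouched. Nothing at hand accounts for the shift.

From the compounds shown here alone, whether the step follows the aromatic ring or its chlorine atoms remains open, and an unsubstituted benzyl group would separate the two. Going by these compounds, how a carboxylic acid or a basic amine on this chain would read is also open.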